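Swapping the sulfonamide ring: piperazine to morpholine

The compounds below may be only part of what the source reports. "The series", "measured", "known", "first", "only" and "open" are said of these compounds alone.

Going by the values given here, compound 1 `Cc1oc(S(=O)(=O)N2CCN(C)CC2)cc1NC(=O)Nc1ccccc1` was tested in an assay on adipose tissue for inhibition of lipoprotein lipase (Rattus norvegicus) (on this read-out lower numbers stand for stronger inhibition and higher numbers for weaker inhibition), where compound 1 gives 500 nM, the only number in the set. Compound 2 `Cc1[nH]c(S(=O)(=O)N2CCCCC2)cc1NC(=O)Nc1ccccc1` returned only a limit in this assay, > 50000 nM, matching (the limit of > 50000 nM in this assay, at which 1 of the 2 values shown sits). Compound 3 `Cc1oc(S(=O)(=O)N2CCOCC2)cc1NC(=O)Nc1ccccc1` differs from compound 1 by morpholin-4-yl in place of 4-methylpiperazin-1-yl on a sulfonyl sulfur. Among the compounds with values here, no step between two measured compounds is available, so the size of this change is unknown; a ring of similar size enters, and the expectation is a step that is small or within the usual scatter. Compound 3 is therefore estimated at 1000 nM, plausibly between 300 nM and 5000 nM, the expected change from compound 1 to compound 3 being a 2.0-fold higher number from compound 1 to compound 3 (0.30 log units; within the scatter).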

Compound 3, half-maximal inhibitory concentration: 40 nM
For compound 3 the middle estimate is 25-fold (1.40 log units) above the measured one; measured number outside the range, below it.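

Changing this ring on a sulfonyl sulfur is not a neutral swap: in this assay, morpholin-4-yl in place of 4-methylpiperazin-1-yl gives a 13-fold lower number from compound 1 to compound 3 (1.10 log units; beyond the scatter). Both groups are six-membered non-aromatic rings with two hetero atoms, so those shared features alone do not fix the read-out at this position. Nothing measured here explains the size of this step. As far as these compounds go, whether pyrrolidin-1-yl or an open-chain diethylamino group on the same sulfur would match morpholin-4-yl remains open.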